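Series notes: methyl in place of fluoro

The source may report more compounds than this note shows. Statements on the series, on what has been measured and on what is new or still open speak of the compounds shown alone.

Measured so far:
compound 1 `COc1cccc(/C=C2\Cc3ccccc3C2=O)c1`: 217000 nM
compound 2 `O=C1/C(=C/c2ccc(F)cc2)CCc2ccccc21`: 49300 nM

Both values come from a functional assay on L1210 cells (Mus musculus) for inhibition; on this read-out higher numbers stand for weaker inhibition and lower numbers for stronger inhibition. Compound 2 stands lowest of the two at 49300 nM, and its gap to compound 1 at 217000 nM lies beyond the scatter. The next entry is compound 3 `Cc1ccc(/C=C2\CCc3ccccc3C2=O)cc1`, which carries methyl in place of fluoro on an aromatic carbon, para to a large group: methyl in place of fluoro on an aromatic carbon. For the measured compounds named here, no two measured compounds here differ in one place only, so the data do not show how this assay responds to a change of this kind. The expected step of a 1.1-fold higher number from compound 2 to compound 3 (0.05 log units; within the scatter) is none beyond the scatter, with neither direction favoured. Compound 3 is expected at 55000 nM, with an estimated range of 22000 nM to 130000 nM.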

Compound 3, half-maximal inhibitory concentration: 161000 nM
Compound 3: middle estimate off by 2.9-fold (0.47 log units), on the low side; measured number outside the range, above it.
By their numbers in this assay, from the lowest: compound 2; then compounds 3 and 1 (each within the scatter of the next).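

In this assay, for the compounds shown here, the swap of methyl in place of fluoro on an aromatic carbon, para to a large group, gives a real change (a 3.3-fold higher number from compound 2 to compound 3 (0.51 log units; beyond the scatter)), and this is the first comparison in which the compounds differ in one place only. It shows that this position responds even to an exchange of one heavy atom for one heavy atom, with no hydrogen-bond donor or acceptor on either side, and that fluoro gives the stronger inhibition of the two. Nothing at hand bears on what lies behind the difference.

The compounds shown give only these two groups at this position, and one step cannot set a trend. Going by these compounds, how an amine, a carboxylic acid or a longer chain would fare at this position remains open.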